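A few compounds are considered here, and "the series" means these few. Any claim that something is new, unique, unknown or untested is made for them only; others in the source may bear on it.

Measured in a functional assay on HeLa cells (Homo sapiens) for inhibition, read by MTT assay, with a stated time of 72 h; on this read-out lower numbers stand for stronger inhibition and higher numbers for weaker inhibition:
- compound 1 `Nc1ncnc2c1c(-c1cnc3[nH]ccc3c1)nn2CC(=O)NO`: "not determined" (no result reported)
- compound 2 `Nc1ncnc2c1c(-c1cnc3[nH]ccc3c1)nn2CCCCCCCCC(=O)NO`: 7470 nM
- compound 3 `Nc1nc2cc(-c3nn(CCCC(=O)NO)c4ncnc(N)c34)ccc2o1`: > 150000 nM, a limit and not a number

In this assay, for the measured compounds named here, compound 2 holds the only actual number, 7470 nM, so it cannot yet be ranked against a second value. Compound 4 `Nc1ncnc2c1c(-c1cnc3[nH]ccc3c1)nn2CCCCCC(=O)NO` is still to be measured. The change is hydroxycarbamoyl in place of 3-(hydroxycarbamoyl)propyl on a saturated chain carbon, five bonds along the chain from an aromatic nitrogen. Going by the values given here, no measured pair isolates this change, so neither direction is favoured. The expected 1.2-fold lower number from compound 2 to compound 4 (0.10 log units; within the scatter) stays within the usual scatter, with compound 2 at 7470 nM as the sole anchor. The estimate for compound 4 is 6000 nM, with an expected range of 1200 nM to 30000 nM.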

Compound 4, half-maximal inhibitory concentration: > 150000 nM
Compound 4 gave a limit, no number; the forecaster's own chance of this, stated with the estimate: 10%; middle value at least 25-fold (1.39 log units) from the limit.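

In this assay, the chain on a saturated chain carbon, five bonds along the chain from an aromatic nitrogen, proves sensitive to shortening: hydroxycarbamoyl in place of 3-(hydroxycarbamoyl)propyl gives an at least 20-fold higher number from compound 2 to compound 4 (1.30 log units; beyond the scatter). Among the compounds shown, this is the first step that isolates chain length on the shared core. The size of the step is only a bound, as compound 4 sits at a limit of the assay and not at a number: the limit of > 150000 nM in this assay, at which 2 of the 4 values shown sit.

Still open, as far as these compounds go, is whether a longer chain ending in hydroxycarbamoyl gives a lower number than compound 2. Also open, from the compounds shown here alone, is whether a carboxylic acid in place of the hydroxycarbamoyl end retains any inhibition.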